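A few compounds are considered here, and "the series" means these few. Any claim that something is new, unique, unknown or untested is made for them only; others in the source may bear on it.

Measured compounds:
- compound 1, `COc1ccc(/C=C/C(=O)Nc2cc(C(=O)c3cc(OC)c(OC)c(OC)c3)cc(OC)c2OC)cc1N`: 13900 nM
- compound 2, `C#CCOc1cccc(/C=C/C(=O)Nc2cc(C(=O)c3cc(OC)c(OC)c(OC)c3)cc(OC)c2OC)c1`: 8400 nM

In a functional assay on ME-180 cells (Homo sapiens) for cytotoxicity, read by MTT assay, with a stated time of 72 h (a lower number here means a stronger inhibitor, a higher number a weaker inhibitor), compound 2 gives 8400 nM, the lowest of the two numbers available, and compound 1 gives 13900 nM. Within the data shown here, the one measured step, a 1.7-fold lower number from compound 1 to compound 2 (0.22 log units; within the scatter), is the only comparison between two compounds that share this core, and it does not separate them beyond the scatter.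

Compound 3, `COc1cc(C(=O)c2cc(OC)c(OC)c(OC)c2)cc(NC(=O)/C=C/c2cc(F)c(F)c(F)c2)c1OC`, has not yet been measured. It differs from compound 2 in one place: 3,4,5-trifluorophenyl in place of 3-(propargyloxy)phenyl on a double-bonded chain carbon bound to a double-bonded chain carbon. Among the measured compounds shown here, no measured step bears directly on this exchange; the only step available, a 1.7-fold lower number from compound 1 to compound 2 (0.22 log units; within the scatter), concerns a different pair of groups at the same place and was itself within the scatter. That step therefore gives no direction for the change to compound 3, and nothing in the two numbers suggests a large movement either way.

Compound 3 is consequently expected to sit close to compound 2, with a step of a 1.1-fold lower number from compound 2 to compound 3 (0.02 log units; within the scatter), and an estimated value of 8000 nM in this assay, within a range of 2500 nM to 25000 nM.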

Compound 3, half-maximal inhibitory concentration: 7100 nM
Compound 3: the middle estimate sits 1.1-fold (0.05 log units) above what was measured; low and high end bracket the measured number.
By their numbers in this assay, from the lowest: compounds 3, 2 and 1 (each within the scatter of the next).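

In this assay, 3,4,5-trifluorophenyl in place of 3-(propargyloxy)phenyl on a double-bonded chain carbon bound to a double-bonded chain carbon gives a 1.2-fold lower number from compound 2 to compound 3 (0.07 log units; within the scatter) and shows that this place accepts a ring carrying fluorine and no oxygen without a change that can be told from the scatter. Against the third group at this place, 3-amino-4-methoxyphenyl, the same ring gives a 2.0-fold lower number from compound 1 to compound 3 (0.29 log units; within the scatter) and so also stays within the scatter, which means that all three compounds, with their different ring substituents, now fall within the scatter of one another and this place has shown no measurable response to the exchange so far. No measurement is at hand that could explain this lack of separation.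

The compounds shown leave open whether any group at this place can move the number beyond the scatter, for instance a carboxylic acid, a dimethylamino group or a pyridine ring in place of the substituted phenyl ring. They also leave open whether a longer chain between the amide carbonyl and the ring would change the picture in this assay at all.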